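Taking One Methyl Away from Compound 2

The source may report more compounds than this note shows. Statements on the series, on what has been measured and on what is new or still open speak of the compounds shown alone.

Measured in a functional assay on HCT-116 cells (Homo sapiens) for antiproliferative activity; on this read-out lower numbers stand for stronger inhibition of growth and higher numbers for weaker inhibition of growth:
- Compound 1 `Cc1ccnc2nc(-c3cccc4ccccc34)cc(O)c12`: < 10 nM (a limit of the assay)
- Compound 2 `Cc1cc(C)c2c(O)cc(-c3cccc4ccccc34)nc2n1`: 380 nM
- Compound 3 `Cc1ccc2c(O)cc(-c3ccc4ccccc4c3)nc2n1`: 3980 nM

Of the two values that are true numbers, compound 2 at 380 nM is the lower, and compound 3 stands higher at 3980 nM. Compound 4 `Cc1ccc2c(O)cc(-c3cccc4ccccc34)nc2n1` carries hydrogen in place of methyl on an aromatic carbon, opposite the ring nitrogen (hydrogen in place of methyl on an aromatic carbon). Going by the values given here, the one measured step of this kind is large: an at least 38-fold higher number from compound 1 to compound 2 (1.57 log units; beyond the scatter). It concerns the other methyl of compound 2, so it gives no direct measure of this change. Nothing beyond the scatter is therefore expected in this assay, with an estimated 1.3-fold lower number from compound 2 to compound 4 (0.10 log units; within the scatter). For compound 4 the expected value is 300 nM, with an estimated range of 60 nM to 1500 nM.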

Compound 4, concentration for 50% growth inhibition: < 10 nM
Compound 4: only a limit was reported; the forecaster's own chance of this, stated with the estimate: 5%; middle value at least 30-fold (1.47 log units) from the limit.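

In this assay, hydrogen in place of methyl on this aromatic carbon, opposite the ring nitrogen, gives an at least 38-fold lower number from compound 2 to compound 4 (1.57 log units; beyond the scatter), so this methyl, which the earlier step did not touch, weighs heavily on the read-out by itself. Compound 4 gives < 10 nM, which is a limit and not a number. The step is therefore only a bound, and its full size cannot be read: the limit of < 10 nM in this assay, at which 2 of the 4 values shown sit.

As far as these compounds go, whether an amine, a methoxy group or a chlorine atom at this position would behave like hydrogen or like methyl stays open. So does whether the same change carries over to the core of compound 3.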